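The source may hold more compounds than are shown below. What is called first, only, known or untested is meant among the compounds shown, and "the series" means these compounds.

Measured compounds in this series:

Compound 1 `Sc1nc(NCc2ccccc2)c2ccccc2n1`: > 100000 nM (a limit of the assay).
Compound 2 `CSc1nc(NCc2ccccc2)c2ccccc2n1`: 88200 nM.
Compound 3 `COc1ccc(CNc2nc(SC)nc3ccccc23)cc1`: 96200 nM.

In an ADME assay on BEAS-2B cells (Homo sapiens) for cytotoxicity, read by MTT assay, with a stated time of 72 h (a lower number here means a stronger inhibitor of growth, a higher number a weaker inhibitor of growth), compound 2 gives 88200 nM. For compound 1 the reading of > 100000 nM in this assay is a limit of the assay, not a number. Compound 3 gives 96200 nM in this assay.

The two cores differ by methoxy in place of hydrogen on an aromatic carbon, and the step is a 1.1-fold higher number from compound 2 to compound 3 (0.04 log units; within the scatter). The other change in the set is hydrogen in place of methyl on a sulfur, for which the step is an at least 1.1-fold higher number from compound 2 to compound 1 (0.05 log units; that floor lies within the scatter); its size has only a floor, set by the limit of > 100000 nM in this assay, at which 1 of the 3 values shown sits.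

Compound 4 `COc1ccc(CNc2nc(S)nc3ccccc23)cc1` is not yet measured. It differs from compound 3 by hydrogen in place of methyl on a sulfur, which is the same change that leads from compound 2 to compound 1, made here on the core that carries the methoxy group; the place of the change reads the same in both cases.

The expectation rests on that single measured precedent. For compound 4 the expected step is a 1.1-fold higher number from compound 3 to compound 4 (0.06 log units; within the scatter) because the same change gave an at least 1.1-fold higher number from compound 2 to compound 1 (0.05 log units; that floor lies within the scatter). Compound 4 is estimated at 110000 nM. The expected range for compound 4 runs from 80000 nM to 160000 nM. Given that compound 1 reached only a limit, compound 4 is also expected to have a substantial chance of returning a limit rather than a number.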

Compound 4, concentration for total growth inhibition: 32500 nM
Estimate against measurement, compound 4: 3.4-fold (0.53 log units) above; measured number outside the range, below it.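

In this assay, hydrogen in place of methyl on a sulfur does not carry over unchanged from one core to the other: on the core with the methoxy group the change gives a 3.0-fold lower number from compound 3 to compound 4 (0.47 log units; beyond the scatter), and this sits apart from the step on the core without that group: the same change on two cores in this assay, an at least 1.1-fold higher number (0.05 log units; that floor lies within the scatter) from compound 2 to compound 1 and a 3.0-fold lower number (0.47 log units; beyond the scatter) from compound 3 to compound 4, at least 3.3-fold (0.52 log units) apart, beyond the scatter of two such steps. Read the other way, methoxy in place of hydrogen on an aromatic carbon also depends on the rest of the molecule, since with hydrogen on the sulfur it gives an at least 3.0-fold lower number from compound 1 to compound 4 (0.48 log units; beyond the scatter), which again sits apart from its counterpart with methyl on the sulfur: the same change on two cores in this assay, a 1.1-fold higher number (0.04 log units; within the scatter) from compound 2 to compound 3 and an at least 3.0-fold lower number (0.48 log units; beyond the scatter) from compound 1 to compound 4, at least 3.3-fold (0.52 log units) apart, beyond the scatter of two such steps. Compound 1 gives > 100000 nM, a limit of the assay and not a number, so the gap between the two steps has only a floor, and this single set of four compounds shows neither a rule for the wider series nor a reason for the difference: the limit of > 100000 nM in this assay, at which 1 of the 4 values shown sits.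

On these data alone, whether the lower number of compound 4 is tied to methoxy, or would also appear with a chlorine atom or a hydroxyl group on that aromatic carbon, stays open. Also open, as far as these compounds go, is how a longer chain on the sulfur, such as ethyl or propyl, would read in this assay on either core.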